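The source may hold more compounds than are shown below. What is called first, only, known or untested is meant among the compounds shown, and "the series" means these compounds.

In a functional assay on HepG2 cells (Homo sapiens) for antiproliferative activity, read by CCK-8 assay, with a stated time of 72 h, tested at 2 uM (on this read-out lower numbers stand for a weaker effect and higher numbers for a stronger effect at the one concentration tested), compound 1 `CC1CCN(c2nc(Cl)nc3c2ncn3Cc2ccc(/C=C/C(=O)Nc3ccccc3N)cc2)CC1` gives 8.73%. Compound 2 `Nc1ccccc1NC(=O)c1ccc(Cn2cnc3c(NCc4ccccc4)nc(Cl)nc32)cc1` gives 7.55% in this assay, and its number lies within the usual scatter of that of compound 1, so neither stands apart from the other. Compound 3 `Nc1ccccc1NC(=O)/C=C/c1ccc(Cn2cnc3c(NCc4ccccc4)nc(Cl)nc32)cc1` differs from compound 2 in one place: 2-((2-aminophenyl)carbamoyl)ethenyl in place of (2-aminophenyl)carbamoyl on an aromatic carbon. Because compound 1, which already carries the entering group, gives 8.73%, no effect beyond the scatter is expected. The step of a number 1.5 percentage points higher from compound 2 to compound 3 (within the scatter) is thus expected to be of no real size. Compound 3 is estimated at 9%, within 3% to 16%.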

Compound 3, a percentage reported as inhibition, at one concentration (the size of the read-out at that concentration, not a potency): 11.5%
The estimate for compound 3 lay 2.5 percentage points below the measured number; measured number inside the range.
By their numbers in this assay, from the lowest: compounds 2, 1 and 3 (each within the scatter of the next).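

In this assay, 2-((2-aminophenyl)carbamoyl)ethenyl in place of (2-aminophenyl)carbamoyl on an aromatic carbon para to a large group gives a number 4 percentage points higher from compound 2 to compound 3 (within the scatter), so this read-out does not separate the two groups at this position. Benzylamino in place of 4-methylpiperidin-1-yl gives a number 2.8 percentage points higher from compound 1 to compound 3 (within the scatter), so that change, made with the ethenyl-containing group present, does not separate them either. Nothing available here bears on these results. From the compounds shown here alone, whether a longer chain or a carboxylic acid at the first position would move the read-out beyond the scatter remains open.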